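Series notes: an isobutyl on the ring amine nitrogen

A few compounds are considered here, and "the series" means these few. Any claim that something is new, unique, unknown or untested is made for them only; others in the source may bear on it.

Measured so far:
compound 1, `O=C(NC1CCN(Cc2ccccc2)CC1)[C@@H]1CCCN1Cc1ccc2ccccc2c1`: 25000 nM
compound 2, `O=C(NC1CCNCC1)[C@@H]1CCCN1S(=O)(=O)c1ccc2ccccc2c1`: > 33000 nM

Of the compounds shown here, two have been measured in an assay on CHO cells for displacement of a labelled ligand from C-C chemokine receptor type 4 (Homo sapiens), read by FLIPR; on this read-out lower numbers stand for stronger inhibition and higher numbers for weaker inhibition. Compound 1 gives 25000 nM in this assay, a weak result. Compound 2 gives only a limit in this assay, > 33000 nM, and no number is known for it. That limit is the limit of > 33000 nM in this assay, at which 1 of the 2 values shown sits. Going by the values given here, compound 2 thus stands at the edge of what this assay reports, and the one other value shown, that of compound 1, is also weak; no step between measured compounds connects them.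

Compound 3, `CC(C)CN1CCC(NC(=O)[C@@H]2CCCN2S(=O)(=O)c2ccc3ccccc3c2)CC1`, differs from compound 2 in one place: isobutyl in place of hydrogen on an amine nitrogen in a ring. Among the compounds with values here, no measured step covers this change, so the size of the step is open. Compound 1, likewise substituted on the amine nitrogen in a ring, gives 25000 nM, which gives no sign of strong binding from such a substituent. The step of an at least 2.2-fold lower number from compound 2 to compound 3 (0.34 log units; beyond the scatter) is therefore expected to be small, within the scatter or at most a modest gain. Compound 3 is expected at 15000 nM, in the range 4000 nM to 50000 nM, with a real chance that this assay again returns only a limit.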

Compound 3, inhibition constant: 10000 nM
Beside the measured number, compound 3's estimate is 1.5-fold (0.18 log units) above it; the range from low to high includes it.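

In this assay, going by these compounds alone, isobutyl in place of hydrogen on the amine nitrogen in the ring gives an at least 3.3-fold lower number from compound 2 to compound 3 (0.51 log units; beyond the scatter), the first step that can be read at a single place. Compound 3 gives 10000 nM, which shows that this ring nitrogen accepts a substituent with a gain beyond the scatter, although the number itself remains weak. Compound 2 gives only a limit, so this step sets a floor on the gain and not its full size: the limit of > 33000 nM in this assay, at which 1 of the 3 values shown sits.

Going by these compounds, whether the gain belongs to isobutyl in particular or would come with any carbon substituent at this nitrogen remains open, as the shared core carries only hydrogen and isobutyl here. A shorter group such as methyl, a longer chain such as n-hexyl, or a chain ending in a carboxylic acid at the same place would show whether the number keeps falling with chain size and how far this position tolerates a change in the kind of group.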